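The compounds below may be only part of what the source reports. "The series", "measured", "known", "first", "only" and "open" are said of these compounds alone.

Measured so far in a functional assay on HeLa cells (Homo sapiens) for antiproliferative activity, with a stated time of 48 h; a higher number here means a weaker inhibitor, a lower number a stronger inhibitor:
- Compound 1 `C=C(Br)C(=O)Nc1ccc(C(=O)/C=C/c2ccccc2OC)cc1`: 1300 nM
- Compound 2 `C=C(Br)C(=O)Nc1ccc(C(=O)/C=C/c2cccc(OC)c2OC)cc1`: 380 nM

Compound 2 has the lower of the two numbers, which makes it the stronger inhibitor of this pair. The next compound, compound 3 `C=C(Br)C(=O)Nc1ccc(C(=O)/C=C/c2ccc(OC)c(OC)c2OC)cc1`, keeps the core of compound 2 and differs in one place, with methoxy in place of hydrogen on an aromatic carbon. The new group is ortho to a methoxy group, meta to a methoxy group and para to a large group.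

For the measured compounds named here, only one measured step bears on this change. It is the same kind of replacement at a different carbon, and it gave a 3.4-fold lower number from compound 1 to compound 2 (0.53 log units; beyond the scatter), a modest gain. One example is thin evidence, so a repeat of the full size cannot be assumed. In this assay, a second step in the same direction is expected, toward a lower number, though probably a somewhat smaller one. The expected change is a 1.9-fold lower number from compound 2 to compound 3 (0.28 log units; within the scatter). For compound 3 the estimated value is 200 nM, with an expected range from 70 nM to 600 nM.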

Compound 3, half-maximal inhibitory concentration: 510 nM
Estimate against measurement, compound 3: 2.6-fold (0.41 log units) below, and the stated range covers the measured number.
By their numbers in this assay, from the lowest: compounds 2 and 3 (each within the scatter of the next); then compound 1.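

In this assay, the new methoxy group does not repeat the earlier gain: the result is a 1.3-fold higher number from compound 2 to compound 3 (0.13 log units; within the scatter), so at this carbon, ortho to a methoxy group and para to a large group, swapping hydrogen for methoxy brings no change that can be told apart from the scatter. The same swap at another carbon of the ring gave a 3.4-fold lower number from compound 1 to compound 2 (0.53 log units; beyond the scatter), so these two steps show that the outcome depends on where the methoxy group is placed, not only on the group itself. Nothing at hand explains why the two carbons behave differently.

On these data alone, it remains open whether another group at this carbon, such as a hydroxyl, an amine or a fluorine atom, or a longer chain such as ethoxy, would move the number beyond the scatter. Also open is how a methoxy group at this carbon would behave without the other two methoxy groups on the ring, since in the compounds shown it appears only alongside them.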